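Extending a Sulfonyl Methyl Group and Expected Permeability

This account rests on a few compounds, and the source may have more. Where it says the series, first, only, none or still open, it means among the compounds named here.

Of the compounds shown here, three sharing one core have been measured in a physicochemical assay for permeability, using PAMPA, at pH 7.4; on this read-out higher numbers stand for higher permeability and lower numbers for lower permeability. Compound 1 `CC(C)(C)NC(=O)NCCS(=O)(=O)NC(=O)c1ccc(Nc2nc(NC3(c4ccc(Cl)cc4)CC3)nc(OCC(F)(F)F)n2)cc1` gives 49 nm/s, compound 2 `CC(C)S(=O)(=O)NC(=O)c1ccc(Nc2nc(NC3(c4ccc(Cl)cc4)CC3)nc(OCC(F)(F)F)n2)cc1` gives 31 nm/s, and compound 3 `CS(=O)(=O)NC(=O)c1ccc(Nc2nc(NC3(c4ccc(Cl)cc4)CC3)nc(OCC(F)(F)F)n2)cc1` gives 11 nm/s, the lowest of the three, since the steps of a 4.5-fold lower number from compound 1 to compound 3 (0.65 log units; beyond the scatter) and a 2.8-fold lower number from compound 2 to compound 3 (0.45 log units; beyond the scatter) both exceed the scatter. Compound 4 `COC(=O)NCCS(=O)(=O)NC(=O)c1ccc(Nc2nc(NC3(c4ccc(Cl)cc4)CC3)nc(OCC(F)(F)F)n2)cc1` differs from compound 3 in one place: ((methoxycarbonyl)amino)methyl in place of hydrogen on a saturated chain carbon bound to a sulfonyl sulfur. Among the measured compounds shown here, the closest precedent is the step from compound 1 to compound 3, where a chain of this kind on the same carbon stood beside the higher number, while the step of a 1.6-fold lower number from compound 1 to compound 2 (0.20 log units; within the scatter) lies within the scatter. Compound 4 is therefore expected to show a modest rise in this assay, a 2.7-fold higher number from compound 3 to compound 4 (0.44 log units; beyond the scatter), to an estimated 30 nm/s with a range of 14 nm/s to 60 nm/s.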

Compound 4, apparent permeability: 39 nm/s
Estimate against measurement, compound 4: 1.3-fold (0.11 log units) below, within the range that was stated.
By their numbers in this assay, from the lowest: compound 3; then compounds 2, 4 and 1 (each within the scatter of the next).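

At this position in this assay, ((methoxycarbonyl)amino)methyl in place of hydrogen gives a 3.5-fold higher number from compound 3 to compound 4 (0.55 log units; beyond the scatter), so a second chain type on this carbon now stands with a higher number. The end of the chain changes little here: methoxy in place of (tert-butyl)amino gives a 1.3-fold lower number from compound 1 to compound 4 (0.10 log units; within the scatter), and 2-((methoxycarbonyl)amino)ethyl in place of isopropyl gives a 1.3-fold higher number from compound 2 to compound 4 (0.10 log units; within the scatter). No measurement shown explains these results. On these data alone, it remains open whether a chain ending in an amine or a carboxylic acid would keep the higher number.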